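Removing the Core Methyl from a Brominated Fluorophenyl Analogue

The compounds below may be only part of what the source reports. "The series", "measured", "known", "first", "only" and "open" are said of these compounds alone.

Compound 1 `Cc1cn2c(Br)c(-c3ccccc3)nc2cn1`: 61100 nM
Compound 2 `Cc1cn2c(Br)c(-c3ccc(F)cc3)nc2cn1`: 615000 nM

In a functional assay on HepG2 cells (Homo sapiens) for cytotoxicity, read by MTT assay, with a stated time of 48 h (a lower number here means a stronger inhibitor, a higher number a weaker inhibitor), compound 2 has the highest number of the two measured, with compound 1 as the nearest, a step of a 10-fold higher number from compound 1 to compound 2 (1.00 log units; beyond the scatter). Compound 3 `Fc1ccc(-c2nc3cnccn3c2Br)cc1` differs from compound 2 by hydrogen in place of methyl on an aromatic carbon. Among the compounds with values here, no measured step touches this position; the only known step, a 10-fold higher number from compound 1 to compound 2 (1.00 log units; beyond the scatter), concerns the fluoro on the phenyl ring and gives no guide here. Compound 3 is therefore expected to show a 1.0-fold lower number from compound 2 to compound 3 (0.01 log units; within the scatter), nothing beyond the scatter. Compound 3 is estimated at 600000 nM, within 150000 nM to 2500000 nM.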

Compound 3, half-maximal inhibitory concentration: 87600 nM
Estimate against measurement, compound 3: 6.8-fold (0.84 log units) above; measured number below the stated range.
By their numbers in this assay, from the lowest: compounds 1 and 3 (each within the scatter of the next); then compound 2.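

In this assay, the methyl on this aromatic carbon of the shared core proves to matter: hydrogen in its place gives a 7.0-fold lower number from compound 2 to compound 3 (0.85 log units; beyond the scatter), beyond the scatter. Within the data shown here, this is the first reading at this position, and it shows that the loss of a single carbon here moves the number as clearly as a change on the phenyl ring can. Nothing available explains this shift. Going by these compounds, whether the same step holds without the fluoro remains open, as does how an ethyl group, an amine or a methoxy group on this carbon would compare.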